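Ethyl to isopropyl carbamate: a branched-chain step in rat liver

This account rests on a few compounds, and the source may have more. Where it says the series, first, only, none or still open, it means among the compounds named here.

In an ADME assay on S9 fraction from liver (Rattus norvegicus), read by LC-MS, with a stated time of 60 min, at 37 degrees C (a higher number here means that more of the compound is left, a lower number that less of the compound is left), three compounds of one series have been measured. Compound 1 `CC(C)C(=O)OCOC(=O)N1CCN(C(=O)c2nc(Nc3cc(C4CC4)[nH]n3)c3cc(Cl)ccc3n2)C[C@H]1C` gives 14%. Compound 2 `CC(OC(=O)C(C)C)OC(=O)N1CCN(C(=O)c2nc(Nc3cc(C4CC4)[nH]n3)c3cc(Cl)ccc3n2)C[C@H]1C` gives 11%. Compound 3 `CCOC(=O)N1CCN(C(=O)c2nc(Nc3cc(C4CC4)[nH]n3)c3cc(Cl)ccc3n2)C[C@H]1C` gives 48.5%, the highest of the three: the step of a number 34.5 percentage points higher from compound 1 to compound 3 (beyond the scatter) and the step of a number 37.5 percentage points higher from compound 2 to compound 3 (beyond the scatter) both stand out clearly. The cores of compound 1 and compound 3 differ as follows: methyl in place of (isopropylcarbonyl)oxy on a saturated chain carbon bound to an oxygen next to a carbonyl group.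

One structural change occurs twice among these compounds. From compound 1 to compound 2 it reads (methyl in place of hydrogen on a saturated chain carbon bound to two oxygens next to a carbonyl group), and it made the step of a number 3 percentage points lower from compound 1 to compound 2 (within the scatter). From compound 3 to the unmeasured compound 4 `CC(C)OC(=O)N1CCN(C(=O)c2nc(Nc3cc(C4CC4)[nH]n3)c3cc(Cl)ccc3n2)C[C@H]1C` it reads (methyl in place of hydrogen on a saturated chain carbon bound to an oxygen next to a carbonyl group and a saturated chain carbon). The two places are not the same: in the first the carbon is bound to two oxygens, in the second to one oxygen and a saturated chain carbon, so this is the same kind of change rather than the same change.

Because the step of a number 3 percentage points lower from compound 1 to compound 2 (within the scatter) stayed within the scatter on the core of compound 1, compound 4 is expected to show a step of about a number 6.5 percentage points higher from compound 3 to compound 4 (within the scatter) from compound 3 in this assay, with the wider range reflecting that the place differs. Compound 4 is thus estimated at 55%, between 35% and 75%.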

Compound 4, percent of the compound remaining: 78.6%
For compound 4 the middle estimate is 23.6 percentage points below the measured one, and the stated range ends below it.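

In this assay, methyl in place of hydrogen behaved very differently at the two places, giving a number 30.1 percentage points higher from compound 3 to compound 4 (beyond the scatter), so the flat result on the core of compound 1 did not carry over to the core of compound 3: the same change on two cores in this assay, a number 3 percentage points lower (within the scatter) from compound 1 to compound 2 and a number 30.1 percentage points higher (beyond the scatter) from compound 3 to compound 4, 33.1 percentage points apart, beyond the scatter of two such steps The exchange of (isopropylcarbonyl)oxy for methyl also depended on its setting, and a number 67.6 percentage points higher from compound 2 to compound 4 (beyond the scatter) was far larger than its counterpart on the other pair: the same change on two cores in this assay, a number 34.5 percentage points higher (beyond the scatter) from compound 1 to compound 3 and a number 67.6 percentage points higher (beyond the scatter) from compound 2 to compound 4, 33.1 percentage points apart, beyond the scatter of two such steps With a number 64.6 percentage points higher from compound 1 to compound 4 (beyond the scatter), compound 4 holds the highest number of the four, but these comparisons rest on a single pair for each change, at places that are not the same, and they show that the size of a step did not transfer here, not why it did not or how it would behave on any other core.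

The compounds shown leave open whether a propyl chain or a tert-butyl group on the oxygen would give a number like that of compound 4 in this assay, and so whether the branch or the added carbon accounts for the step. They also leave open what becomes of the part of each compound that is no longer found, since the read-out follows only the compound that remains.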